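Swapping one guanidine for an amidine on a paired scaffold

The compounds below may be only part of what the source reports. "The series", "measured", "known", "first", "only" and "open" are said of these compounds alone.

Compound 2 `N=C(N)Nc1ccc(C(=O)NCC[C@H]2C(=O)N(CC(=O)O)CCN2C(=O)CNC(=O)c2ccc(NC(=N)N)cc2)cc1` is a symmetric molecule carrying two guanidine-bearing aryl groups. In a functional assay for inhibition, with Cavia porcellus as the target (a lower number here means a stronger inhibitor, a higher number a weaker inhibitor), compound 2 gives 97 nM, and its amidine counterpart, compound 1 `N=C(N)c1ccc(C(=O)NCC[C@H]2C(=O)N(CC(=O)O)CCN2C(=O)CNC(=O)c2ccc(C(=N)N)cc2)cc1`, gives 190 nM; these two numbers lie within the usual scatter of each other. Compound 3 `N=C(N)Nc1ccc(C(=O)NCC[C@H]2C(=O)N(CC(=O)O)CCN2C(=O)CNC(=O)c2ccc(C(=N)N)cc2)cc1` is the hybrid: a group of 3 heavy atoms (1 carbon, 2 nitrogen; no ring) in place of a group of 4 heavy atoms (1 carbon, 3 nitrogen; no ring), on an aromatic carbon. Among the compounds with values here, no measured pair shows this change on its own. Since compound 1 and compound 2 read alike, the expected step from compound 2 to compound 3 is a 1.3-fold higher number from compound 2 to compound 3 (0.13 log units; within the scatter), essentially none beyond the scatter. Compound 3 is therefore estimated at 130 nM, plausibly between 50 nM and 350 nM in this assay.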

Compound 3, half-maximal inhibitory concentration: 37 nM
For compound 3 the middle estimate is 3.5-fold (0.55 log units) above the measured one; the whole stated range lies above it.
By their numbers in this assay, from the lowest: compound 3; then compounds 2 and 1 (each within the scatter of the next).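

Neither matched compound predicts this: with an amidine in place of a guanidine, the change gives a 2.6-fold lower number from compound 2 to compound 3 (0.42 log units; beyond the scatter) in this assay, and with a guanidine in place of an amidine on the other aryl group, it gives a 5.1-fold lower number from compound 1 to compound 3 (0.71 log units; beyond the scatter) in the same test. Compound 3, with one group of each kind, therefore stands apart from both compounds that carry two identical groups. No measurement here explains this gain. From the compounds shown here alone, the reverse arrangement of the guanidine and amidine remains open, so the importance of which aryl group carries which is unknown. Going by these compounds, whether a simple amine on this aromatic carbon would keep the gain is also open.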